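The source may hold more compounds than are shown below. What is called first, only, known or untested is meant among the compounds shown, and "the series" means these compounds.

In a functional assay on SMMC-7721 cells (Homo sapiens) for cytotoxicity, read by MTT assay, with a stated time of 24 h (a higher number here means a weaker inhibitor, a lower number a stronger inhibitor), compound 3 (`O=C1/C(=C/c2cccnc2)CN(S(=O)(=O)c2ccccc2)C/C1=C\c1ccccc1C(F)(F)F`) gives 10900 nM, and compound 1 (`O=C1/C(=C/c2ccncc2)CN(S(=O)(=O)c2ccccc2)C/C1=C\c1ccccc1F`) gives 17500 nM, within the scatter of compound 3. Compound 2 (`O=C1/C(=C/c2cccnc2)CNC/C1=C\c1ccccc1C(F)(F)F`) gives 5100 nM, and placing phenylsulfonyl on its ring amine nitrogen produces a 2.1-fold higher number from compound 2 to compound 3 (0.33 log units; beyond the scatter). Compound 4 (`O=C1/C(=C/c2ccncc2)CN(S(=O)(=O)c2ccccc2)C/C1=C\c1ccccc1C(F)(F)F`) is still unmeasured and differs from compound 3 in one place: pyridin-4-yl in place of pyridin-3-yl on a double-bonded chain carbon bound to a double-bonded ring carbon. Going by the values given here, the one measured step concerns a different change, so no measured step isolates this swap. Compound 1 already carries pyridin-4-yl but also differs from compound 3 in another group, and the two values lie within the scatter. No step beyond the scatter is therefore expected in this assay. The estimated step is a 1.1-fold higher number from compound 3 to compound 4 (0.04 log units; within the scatter). For compound 4 the expected value is 12000 nM, with an estimated range from 6000 nM to 22000 nM.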

Compound 4, half-maximal inhibitory concentration: 6540 nM
Compound 4: the middle estimate sits 1.8-fold (0.26 log units) above what was measured; the measured number falls inside the stated range.
By their numbers in this assay, from the lowest: compounds 2, 4, 3 and 1 (each within the scatter of the next, the first and the last beyond it).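

In this assay the swap to pyridin-4-yl from pyridin-3-yl, now seen on its own, gives a 1.7-fold lower number from compound 3 to compound 4 (0.22 log units; within the scatter) so this position shows no change beyond the scatter for this pair. Going by these compounds alone, with pyridin-4-yl held in place, trifluoromethyl in place of fluoro on an aromatic carbon gives a 2.7-fold lower number from compound 1 to compound 4 (0.43 log units; beyond the scatter) which is the first single-place step at that aromatic carbon. No supporting data shown here account for either step. As far as these compounds go, whether pyridin-2-yl at the first position would also stay within the scatter remains open. So does how chloro or methoxy on that aromatic carbon would compare.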